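One More Chain Carbon in a Series at the Limit

The source may report more compounds than this note shows. Statements on the series, on what has been measured and on what is new or still open speak of the compounds shown alone.

Compound 1 `COc1cc(-c2nccn2C)cc(OC)c1OC`, compound 2 `CCCn1ccnc1-c1cc(OC)c(OC)c(OC)c1` and compound 3 `CCCCn1ccnc1-c1cc(OC)c(OC)c(OC)c1` share one core and differ only in the chain on an aromatic nitrogen. In a functional assay on HT-29 cells (Homo sapiens) for antiproliferative activity, read by MTT assay, with a stated time of 72 h (on this read-out lower numbers stand for stronger inhibition and higher numbers for weaker inhibition), compound 1 gives > 100000 nM, which is a limit and not a number. Compound 2 gives > 100000 nM, again a limit. Compound 3 gives > 100000 nM, also a limit, so it has no number of its own. Going by the values given here, the series so far sits at the limit of > 100000 nM in this assay, at which 3 of the 3 values shown sit, and no order among its compounds can be read.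

Compound 4 `CCCCCn1ccnc1-c1cc(OC)c(OC)c(OC)c1` differs from compound 3 by one change: methyl in place of hydrogen on a saturated chain carbon, four bonds along the chain from an aromatic nitrogen. Among the compounds with values here, the closest precedent is a step that the two limits leave unreadable from compound 2 to compound 3, the same kind of addition one bond nearer the nitrogen. The longer additions, a step that the two limits leave unreadable from compound 1 to compound 2 and a step that the two limits leave unreadable from compound 1 to compound 3, also bear on it. None of these steps has a measurable size, so they offer no trend to extend. The expected result is a number no higher from compound 3 to compound 4 (the limit leaves the size open), with no direction that the data could support. For compound 4 the estimated value is 100000 nM, expected to lie between 30000 nM and 200000 nM, quite possibly reported as a limit again.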

Compound 4, half-maximal inhibitory concentration: 60100 nM
For compound 4 the middle estimate is 1.7-fold (0.22 log units) above the measured one; measured number inside the range.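

Methyl in place of hydrogen, four bonds along the chain from an aromatic nitrogen, is the one change here that takes a compound off the limit in this assay, leaving compound 4 as the only compound shown with a number of its own: the limit of > 100000 nM in this assay, at which 3 of the 4 values shown sit.

Set against the shorter chains, that number gives an at least 1.6-fold lower number from compound 3 to compound 4 (0.22 log units; that floor lies within the scatter), along with an at least 1.6-fold lower number from compound 2 to compound 4 (0.22 log units; that floor lies within the scatter) and an at least 1.6-fold lower number from compound 1 to compound 4 (0.22 log units; that floor lies within the scatter). Each of these is a floor and not a size, since the other three compounds stand only as limits, and the steps among those three cannot be read, so the true gap from any of them to compound 4 could be small or much larger.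

Whether a longer chain, such as hexyl or octyl, would bring the number lower still, or whether it would stop changing, remains an open question. On these data alone, it is also open whether the chain's length is what counts, which a branched chain with the same carbons, or an amine or a carboxylic acid at the chain's end, could help to separate.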